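This account rests on a few compounds, and the source may have more. Where it says the series, first, only, none or still open, it means among the compounds named here.

Of the compounds shown here, two have so far been tested in an ADME assay on BJ cells (Homo sapiens) for cytotoxicity, read by CellTiter-Glo and resazurin assay, with a stated time of 72 h; a higher number here means that more compound is needed for the effect, a lower number that less compound is needed. Compound 1 `CC(=O)Nc1cccc(-c2ccc(C(=O)N(Cc3cccc(OCCCCCC(=O)O)c3)C(C)C)cc2)c1` gives > 26000 nM, which is a limit of the assay rather than a measured number. Compound 2 `CCOC(=O)CCCCCOc1cccc(CN(C(=O)c2ccc(-c3ccc(C(C)=O)s3)cc2)C(C)C)c1` likewise gives > 26000 nM, again a limit and not a number. For the measured compounds named here, compound 2 therefore stands at the edge of what this assay can report, and the only other value shown sits at the same place: the limit of > 26000 nM in this assay, at which 2 of the 2 values shown sit. Going by the values given here, neither compound showed harm to the cells within the range tested, so there is no measured step to lean on.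

Compound 3 `CCOC(=O)CCCCCOc1cccc(CN(C(=O)c2ccc(Br)cc2)C(C)C)c1` has not yet been tested in this assay. It is derived from compound 2 by a single change: bromo in place of 5-acetylthiophen-2-yl on an aromatic carbon. Everything else in the molecule stays the same.

With both known values sitting at the limit, the step that the limit leaves unreadable from compound 2 to compound 3 is expected to be none beyond the usual scatter. Compound 3 is expected to give about 40000 nM, within a range from 15000 nM to 100000 nM, and most probably the assay will again report only a limit.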

Compound 3, half-maximal effective concentration: > 26000 nM
Compound 3 ended at the assay's limit (the forecaster's own chance of this, stated with the estimate: 80%); the middle value does not contradict the limit.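

Compound 2 and compound 3 both end at the limit of this assay rather than at a number, so no step between them can be read: the limit of > 26000 nM in this assay, at which 3 of the 3 values shown sit.

The compounds shown leave open whether any of them would harm the cells at a higher concentration, and so whether bromo and 5-acetylthiophen-2-yl differ at all in this respect.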